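A Methyl Added to the Ester Chain of Compound 2

The source may report more compounds than this note shows. Statements on the series, on what has been measured and on what is new or still open speak of the compounds shown alone.

Compound 1, `COc1ccc(-c2oc3c(CC=C(C)C)c(OCCCOC(=O)CCCC(=O)O)cc(O)c3c(=O)c2OCCCOC(=O)CCCC(=O)O)cc1`, gives 2200 nM in a functional assay on MCF7 cells (Homo sapiens) for cytotoxicity, read by MTT assay; a lower number here means a stronger inhibitor, a higher number a weaker inhibitor.
Compound 2, `CCOC(=O)COc1c(-c2ccc(OC)cc2)oc2c(CC=C(C)C)c(O)cc(O)c2c1=O`, gives > 100000 nM in this assay.
Compound 3, `COc1ccc(-c2oc3c(CC=C(C)C)c(OCCO)cc(O)c3c(=O)c2OCCO)cc1`, gives > 100000 nM in this assay.

Only compound 1 returns a number. For compound 2 the value is a limit of the assay, not a number. For compound 3 the value is likewise a limit. The picture is summed up by the limit of > 100000 nM in this assay, at which 2 of the 3 values shown sit. Within the data shown here, compound 2 therefore stands at the weak end of what was measured, with one further value at the same limit beside it, and no step between measured compounds is given that would show how a small change moves the result.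

Compound 4, `CCOC(=O)C(C)Oc1c(-c2ccc(OC)cc2)oc2c(CC=C(C)C)c(O)cc(O)c2c1=O`, differs from compound 2 in one place: methyl in place of hydrogen on a saturated chain carbon bound to a carbonyl carbon and an oxygen on an aromatic ring. Among the measured compounds shown here, with no measured step to lean on, a shift in this assay of no more than the scatter is expected, in either direction. The expected step from compound 2 to compound 4 is a number no higher from compound 2 to compound 4 (the limit leaves the size open). Compound 4 is estimated at 100000 nM, within 30000 nM to 300000 nM, most likely reported again as a limit.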

Compound 4, half-maximal inhibitory concentration: 4700 nM
Beside the measured number, compound 4's estimate is 21-fold (1.33 log units) above it; the whole stated range lies above it.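

In this assay the one step shown is an at least 21-fold lower number from compound 2 to compound 4 (1.32 log units; beyond the scatter) and it is the first sign that this position responds at all. A single methyl on a saturated chain carbon bound to a carbonyl carbon and an oxygen on an aromatic ring, turning (ethoxycarbonyl)methoxy into 1-(ethoxycarbonyl)ethoxy, is enough to give compound 4 a measured number. The full size of the step stays unknown, since the value of compound 2 is a limit of the assay and not a number: the limit of > 100000 nM in this assay, at which 2 of the 4 values shown sit.

The compounds shown leave open whether a longer chain on that same carbon would lower the number further. They also leave open whether the change would hold with a carboxylic acid in place of the ethyl ester.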